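Replacing a Hydroxy Group with a Selenium-Bearing Group

The source may hold more compounds than are shown below. What is called first, only, known or untested is meant among the compounds shown, and "the series" means these compounds.

Three compounds share one core and differ only in the group on the carbonyl carbon. In a functional assay on KYSE-450 cells (Homo sapiens) for inhibition, read by MTT assay, with a stated time of 48 h (on this read-out lower numbers stand for stronger inhibition and higher numbers for weaker inhibition), compound 1 `COc1ccc(CN(C(=O)C(C)Br)c2cc(OC)c(OC)c(OC)c2)cc1O` gives 160 nM and compound 2 `C/C=C/C=C/C(=O)N(Cc1ccc(OC)c(O)c1)c1cc(OC)c(OC)c(OC)c1` gives 180 nM in this test, a pair separated by a 1.1-fold higher number from compound 1 to compound 2 (0.05 log units; within the scatter). Compound 3 `COc1ccc(CN(C(=O)CO)c2cc(OC)c(OC)c(OC)c2)cc1O` gives 370 nM, the highest number of the three.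

Compound 4 `COc1ccc(CN(C(=O)C[Se]C#N)c2cc(OC)c(OC)c(OC)c2)cc1O` keeps the core but changes compound 3 by a group of 3 heavy atoms (1 carbon, 1 nitrogen, 1 selenium; no ring) in place of one oxygen atom, on a saturated chain carbon bound to a carbonyl carbon: a group of 3 heavy atoms replaces one oxygen atom, on a saturated chain carbon bound to a carbonyl carbon.

Going by the values given here, two measured steps bear on this change: a 2.3-fold higher number from compound 1 to compound 3 (0.36 log units; beyond the scatter) and a 2.1-fold higher number from compound 2 to compound 3 (0.31 log units; beyond the scatter). Both are modest and both end at the hydroxymethyl compound, while neither involves selenium, so they offer only loose guidance. Undoing the hydroxy group may therefore recover a modest gain in this assay, and the expected change is a 3.1-fold lower number from compound 3 to compound 4 (0.49 log units; beyond the scatter) in this test. Compound 4 is estimated at 120 nM, with an expected range from 30 nM to 350 nM in this test.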

Compound 4, half-maximal inhibitory concentration: 280 nM
Estimate against measurement, compound 4: 2.3-fold (0.37 log units) below; low and high end bracket the measured number.
By their numbers in this assay, from the lowest: compounds 1, 2, 4 and 3 (each within the scatter of the next, the first and the last beyond it).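

In this assay the selenium-bearing group in place of the hydroxy gives a 1.3-fold lower number from compound 3 to compound 4 (0.12 log units; within the scatter) and so cannot be told apart from it at this saturated chain carbon bound to a carbonyl carbon. Compound 3 stood beyond the scatter of both other compounds, yet the new steps, a 1.6-fold higher number from compound 2 to compound 4 (0.19 log units; within the scatter) and a 1.8-fold higher number from compound 1 to compound 4 (0.24 log units; within the scatter), leave compound 4 within the scatter of each, so this position accepts the group of 3 heavy atoms without a readable loss or gain. No measurement on hand explains this result.

What the compounds shown leave open is whether selenium itself matters, which a matching group with sulfur in its place could test. An amine or a carboxylic acid on the same chain carbon would show how far this tolerance extends.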